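Adding a Second Chloro to Compound 1

The compounds below may be only part of what the source reports. "The series", "measured", "known", "first", "only" and "open" are said of these compounds alone.

Three compounds with a shared core were tested in a functional assay on OVCAR-4 cells (Homo sapiens) for cytotoxicity, read by sulforhodamine B assay, with a stated time of 48 h; on this read-out lower numbers stand for stronger inhibition of growth and higher numbers for weaker inhibition of growth. Compound 1 `ClCc1cccc(Cn2cnc3ncnc(Cl)c32)c1` gives 15800 nM, the second highest of the three numbers. Compound 3 `ClCc1ccccc1Cn1cnc2ncnc(Cl)c21` gives 20400 nM, which lies within the scatter of compound 1. Compound 2 `ClCc1ccc(Cn2cnc3nc(Cl)nc(Cl)c32)cc1` gives 4160 nM, a number beyond the scatter and below that of compound 1. Compound 4 `ClCc1cccc(Cn2cnc3nc(Cl)nc(Cl)c32)c1` has not been measured. It differs from compound 1 by chloro in place of hydrogen on an aromatic carbon, a chloro in place of hydrogen on an aromatic carbon. Within the data shown here, no measured pair shows this change alone, but compound 2 carries the same second chloro and gives the lowest number of the three. A moderate step toward a lower number is therefore expected, a 2.6-fold lower number from compound 1 to compound 4 (0.42 log units; beyond the scatter). Compound 4 is estimated at 6000 nM, with a range from 2500 nM to 15000 nM.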

Compound 4, concentration for total growth inhibition: 2950 nM
Compound 4: middle estimate off by 2.0-fold (0.31 log units), on the high side; the range from low to high includes it.
By their numbers in this assay, from the lowest: compounds 4 and 2 (each within the scatter of the next); then compounds 1 and 3 (each within the scatter of the next).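

Replacing hydrogen with chloro on the aromatic carbon between two ring nitrogen atoms gives a 5.4-fold lower number from compound 1 to compound 4 (0.73 log units; beyond the scatter) in this assay as a step beyond the scatter. Among these compounds, this is the first pair that isolates this change, and it shows that the second chloro alone is enough to lower the number on the shared core. Nothing measured here explains the step. Only hydrogen and chloro appear at this position among these compounds. On these data alone, whether an amine or a methoxy group there would also lower the number remains open.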